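Swapping 3-(dimethylamino)propyl for pyridin-4-yl in compound 3

A few compounds are considered here, and "the series" means these few. Any claim that something is new, unique, unknown or untested is made for them only; others in the source may bear on it.

Measured in a functional assay on HT-29 cells (Homo sapiens) for inhibition, read by CellTiter-Glo, with a stated time of 72 h; on this read-out lower numbers stand for higher toxicity in this test and higher numbers for lower toxicity in this test:
Compound 1 `CC1=C(CC(=O)NCCN(C)C)c2cc(F)ccc2/C1=C\c1nc2ccccc2s1`: 1570 nM
Compound 2 `CC1=C(CC(=O)N2CCN(CCCN(C)C)CC2)c2cc(F)ccc2/C1=C\c1nc2ccccc2s1`: 1620 nM

Compound 2 stands level with compound 1, since a 1.0-fold higher number from compound 1 to compound 2 (0.01 log units; within the scatter). Compound 3 `CC1=C(CC(=O)N2CCN(c3ccncc3)CC2)c2cc(F)ccc2/C1=C\c1nc2ccccc2s1` has pyridin-4-yl in place of 3-(dimethylamino)propyl on an amine nitrogen in a ring. For the measured compounds named here, the only measured step, a 1.0-fold higher number from compound 1 to compound 2 (0.01 log units; within the scatter), changed the same part of the molecule, but no measured compound carries pyridin-4-yl, so the evidence is thin. No change beyond the scatter is therefore expected in this assay. The expected step is a 1.1-fold lower number from compound 2 to compound 3 (0.03 log units; within the scatter). For compound 3 the estimate is 1500 nM, with an expected range of 600 nM to 3800 nM.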

Compound 3, half-maximal cytotoxic concentration: 5250 nM
The estimate for compound 3 lay 3.5-fold (0.54 log units) below the measured number; the measured number lies above the stated range.
By their numbers in this assay, from the lowest: compounds 1 and 2 (each within the scatter of the next); then compound 3.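

At this amine nitrogen in a ring, the group does make a difference: in this assay, pyridin-4-yl in place of 3-(dimethylamino)propyl gives a 3.2-fold higher number from compound 2 to compound 3 (0.51 log units; beyond the scatter), which means lower toxicity in this test. Replacing (2-(dimethylamino)ethyl)amino with 4-(pyridin-4-yl)piperazin-1-yl gives a similar result, a 3.3-fold higher number from compound 1 to compound 3 (0.52 log units; beyond the scatter), so a ring on this nitrogen separates compound 3 from both open-chain amine compounds. Nothing at hand explains the shift. On these data alone, whether a phenyl ring or a pyridin-3-yl group on the same nitrogen would give the same result remains open.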